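The source may report more compounds than this note shows. Statements on the series, on what has been measured and on what is new or still open speak of the compounds shown alone.

Series notes on a functional assay on HT-29 cells (Homo sapiens) for inhibition, read by MTT assay, with a stated time of 48 h; on this read-out lower numbers stand for stronger inhibition and higher numbers for weaker inhibition. Compound 1 `COc1cc(/C=C/c2ccc(NC(=O)/C=C/c3ccc(OC)c(OC)c3)cc2)cc(OC)c1` gives 960 nM. Compound 2 `COc1cc(/C=C/c2ccc(NC(=O)/C=C/c3ccc(C(F)(F)F)cc3)cc2)cc(OC)c1` gives 1780 nM, and compound 3 `COc1cc(/C=C/c2ccc(NC(=O)/C=C/c3ccccc3F)cc2)cc(OC)c1` gives 2820 nM. Compound 2 sits among these three numbers without a gap beyond the scatter on either side: a 1.9-fold higher number from compound 1 to compound 2 (0.27 log units; within the scatter) and a 1.6-fold higher number from compound 2 to compound 3 (0.20 log units; within the scatter); only a 2.9-fold higher number from compound 1 to compound 3 (0.47 log units; beyond the scatter) goes beyond it. Compound 4 `COc1cc(/C=C/c2ccc(NC(=O)/C=C/c3ccc(F)cc3F)cc2)cc(OC)c1` differs from compound 2 in one place: 2,4-difluorophenyl in place of 4-(trifluoromethyl)phenyl on a double-bonded chain carbon bound to a double-bonded chain carbon. Going by the values given here, of the measured steps, a 1.6-fold higher number from compound 2 to compound 3 (0.20 log units; within the scatter) bears most directly on this change, as it too exchanges 4-(trifluoromethyl)phenyl for a fluorine-bearing phenyl; the second fluorine has no measured counterpart. A step in this assay staying within the scatter, if anything toward a higher number, is therefore expected, a 1.3-fold higher number from compound 2 to compound 4 (0.11 log units; within the scatter). Compound 4 is estimated at 2300 nM, range 1100 nM to 4800 nM.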

Compound 4, half-maximal inhibitory concentration: 18100 nM
Compound 4: the middle estimate sits 7.9-fold (0.90 log units) below what was measured; measured number above the stated range.
By their numbers in this assay, from the lowest: compounds 1, 2 and 3 (each within the scatter of the next, the first and the last beyond it); then compound 4.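

In this assay this place on the double-bonded chain carbon proves far less forgiving than the first three compounds suggested, with large steps in both (a 10-fold higher number from compound 2 to compound 4 (1.01 log units; beyond the scatter)) and (a 19-fold higher number from compound 1 to compound 4 (1.28 log units; beyond the scatter)). A single fluoro in place of hydrogen on an aromatic carbon is the only difference in (a 6.4-fold higher number from compound 3 to compound 4 (0.81 log units; beyond the scatter)), so one added fluorine is enough to give a step beyond the scatter. No available evidence bears on this result. Still open, going by these compounds, is how 4-fluorophenyl, or a phenyl bearing an amine or a carboxylic acid, would read in this place.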